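The compounds below may be only part of what the source reports. "The series", "measured", "known", "first", "only" and "open" are said of these compounds alone.

Three compounds share one core and differ only in the aryl group attached to it. In a functional assay on HCT-116 cells (Homo sapiens) for cytotoxicity, read by MTT assay, with a stated time of 48 h (on this read-out higher numbers stand for weaker inhibition and lower numbers for stronger inhibition), compound 1 `Cc1nc2c3ccccc3ccc2c2nc3c(ccc4ccccc43)c(-c3cccnc3)c12` gives 34200 nM. Compound 2 `COc1ccc(-c2c3ccc4ccccc4c3nc3c2c(C)nc2c4ccccc4ccc32)cc1` reaches only the limit of this assay, > 80000 nM. Compound 3 `Cc1nc2c3ccccc3ccc2c2nc3c(ccc4ccccc43)c(-c3ccccc3Cl)c12` gives 48200 nM, the higher of the two numbers shown, though a 1.4-fold higher number from compound 1 to compound 3 (0.15 log units; within the scatter), and an at least 1.6-fold lower number from compound 2 to compound 3 (0.22 log units; that floor lies within the scatter). Compound 4 `Cc1nc2c3ccccc3ccc2c2nc3c(ccc4ccccc43)c(-c3cc(O)nc4ccccc34)c12` carries the change (2-hydroxyquinolin-4-yl in place of 2-chlorophenyl on an aromatic carbon). Within the data shown here, the steps that bear on it, an at least 2.3-fold higher number from compound 1 to compound 2 (0.36 log units; beyond the scatter) and a 1.4-fold higher number from compound 1 to compound 3 (0.15 log units; within the scatter), show that exchanging this aryl group either moves the number little or raises it. For compound 4 a step of a 1.1-fold lower number from compound 3 to compound 4 (0.03 log units; within the scatter) is therefore expected, not beyond the scatter. Compound 4 is estimated at 45000 nM, between 15000 nM and 120000 nM.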

Compound 4, half-maximal inhibitory concentration: 4630 nM
For compound 4 the middle estimate is 9.7-fold (0.99 log units) above the measured one; the whole stated range lies above it.
By their numbers in this assay, from the lowest: compound 4; then compounds 1 and 3 (each within the scatter of the next). At a limit, above all of these: compound 2.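

In this assay, this aryl position proves able to lower the number, not only hold or raise it as the earlier exchanges did: 2-hydroxyquinolin-4-yl gives a 10-fold lower number from compound 3 to compound 4 (1.02 log units; beyond the scatter) and a 7.4-fold lower number from compound 1 to compound 4 (0.87 log units; beyond the scatter). Compound 2 stands at a limit, so an at least 17-fold lower number from compound 2 to compound 4 (1.23 log units; beyond the scatter) is only a floor: the limit of > 80000 nM in this assay, at which 1 of the 4 values shown sits.

The compounds shown do not separate the effect of the added fused ring from that of the hydroxyl group. A plain quinolin-4-yl group, or an amine in place of the hydroxyl, would be needed to tell these apart.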